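A few compounds are considered here, and "the series" means these few. Any claim that something is new, unique, unknown or untested is made for them only; others in the source may bear on it.

Measured in a functional assay on cells (Homo sapiens) for inhibition, read by MTT assay, with a stated time of 48 h; a higher number here means a weaker inhibitor, a lower number a stronger inhibitor:
Compound 1 (`O=C(CCCOc1no[n+]([O-])c1S(=O)(=O)c1ccccc1)NO`): 22000 nM
Compound 2 (`O=C(CCCCCCOc1no[n+]([O-])c1S(=O)(=O)c1ccccc1)NO`): "not determined" (no result reported)
Compound 3 (`O=C(CCCCCCCOc1no[n+]([O-])c1S(=O)(=O)c1ccccc1)NO`): "not determined" (no result reported)

Compound 3 has no single number to stand on. Its entry in this assay reads ("not determined" (no result reported)), and compound 2 is in the same position, so compound 1 alone carries a figure. The next compound, compound 4 (`O=C(NO)OCCOCCOc1no[n+]([O-])c1S(=O)(=O)c1ccccc1`), has yet to be measured. Going from compound 3 to compound 4, the structural change (2-((hydroxycarbamoyl)oxy)ethoxy in place of 5-(hydroxycarbamoyl)pentyl on a saturated chain carbon, two bonds along the chain from an oxygen on an aromatic ring) puts 2-((hydroxycarbamoyl)oxy)ethoxy in place of 5-(hydroxycarbamoyl)pentyl on a saturated chain carbon, two bonds along the chain from an oxygen on an aromatic ring. Within the data shown here, no step between measured compounds exists to size this change. Among the measured compounds shown here, the only anchor is compound 1 (22000 nM), and no shift beyond the usual scatter from that figure is expected, in either direction. The uncertainty stays wide, since a single number supports the expectation. Compound 4 is estimated at 18000 nM with an expected range from 5000 nM to 65000 nM in this read-out.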

Compound 4, half-maximal inhibitory concentration: 19400 nM
Compound 4: middle estimate off by 1.1-fold (0.03 log units), on the low side, and the stated range covers the measured number.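

In this assay, among these compounds, the exchange of (hydroxycarbamoyl)methyl for 2-((hydroxycarbamoyl)oxy)ethoxy on a saturated chain carbon, two bonds along the chain from an oxygen on an aromatic ring, gives the first readable step at this position: a 1.1-fold lower number from compound 1 to compound 4 (0.05 log units; within the scatter). The two compounds therefore cannot be told apart in this read-out, even though the entering group is the larger of the two and carries a carbamate-type link in its chain, so this particular change leaves the number where it stood. No supporting measurement is available to explain this result.

As far as these compounds go, how the 5-(hydroxycarbamoyl)pentyl chain of compound 3 compares with these two groups remains open. So does whether a carboxylic acid or an amine in place of the hydroxycarbamoyl end would hold the number at this position.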